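Compound 3 to compound 4: changing the carbonyl substituent

The source may report more compounds than this note shows. Statements on the series, on what has been measured and on what is new or still open speak of the compounds shown alone.

In a functional assay on the whole organism for inhibition, with Mus musculus as the target (on this read-out lower numbers stand for an effect already at smaller amounts and higher numbers for an effect only at larger amounts of compound), three compounds on a shared core have been measured. Compound 1 (`CCNC(=O)Nc1cccc2c1CN(C)CC2c1ccccc1`) gives 54 mg/kg, compound 2 (`CCOC(=O)Nc1cccc2c1CN(C)CC2c1ccccc1`) gives about 4 mg/kg and compound 3 (`CN1Cc2c(NC(=O)OCc3ccccc3)cccc2C(c2ccccc2)C1`) gives 16 mg/kg. Compound 3 therefore holds the middle place among the three numbers, with both gaps beyond the scatter: a 3.4-fold lower number from compound 1 to compound 3 (0.53 log units; beyond the scatter), and a 4.0-fold higher number from compound 2 to compound 3 (0.60 log units; beyond the scatter).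

The next compound is compound 4 (`CN1Cc2c(NC(=O)CN3CCCC3)cccc2C(c2ccccc2)C1`), not yet measured, with (pyrrolidin-1-yl)methyl in place of benzyloxy on a carbonyl carbon. Going by the values given here, no measured step makes this exchange. The closest evidence is the other changes on that carbonyl carbon, including the large 14-fold lower number from compound 1 to compound 2 (1.13 log units; beyond the scatter). Ethoxy and benzyloxy both give lower numbers than ethylamino, and no compound goes against this, although three compounds are a thin base. Compound 4 also gives up an oxy group, and compound 1, at 54 mg/kg, is the only measured case without one. A modest move towards higher numbers is therefore expected, with wide uncertainty. The expected step in this assay is a 2.3-fold higher number from compound 3 to compound 4 (0.35 log units; beyond the scatter). For compound 4 the estimated value is 36 mg/kg, with an expected range of 9 mg/kg to 130 mg/kg.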

Compound 4, dose for half-maximal effect: about 25 mg/kg
For compound 4 the middle estimate is 1.4-fold (0.16 log units) above the measured one; the measured number falls inside the stated range.
By their numbers in this assay, from the lowest: compound 2; then compounds 3 and 4 (each within the scatter of the next); then compound 1.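

In this assay, the carbonyl carbon also accepts a substituent that is neither an oxy group nor ethylamino: with (pyrrolidin-1-yl)methyl replacing benzyloxy, the result is a 1.6-fold higher number from compound 3 to compound 4 (0.19 log units; within the scatter), so the two groups cannot be told apart on this read-out. The oxy group is therefore not required for a number below that of the ethylamino compound, as shown by a 2.2-fold lower number from compound 1 to compound 4 (0.33 log units; beyond the scatter), although ethoxy remains clearly ahead, with a 6.3-fold higher number from compound 2 to compound 4 (0.80 log units; beyond the scatter). Nothing available explains these differences between the substituents.

Still open, going by these compounds, is whether the result belongs to the pyrrolidine ring itself or to an amine on that methyl group more generally, which dimethylaminomethyl, piperidin-1-ylmethyl or morpholin-4-ylmethyl would begin to separate. Also open, on these data alone, is how a longer chain between the carbonyl carbon and the pyrrolidine would read, and whether a small alkyl group without any amine would sit with compound 4 or with compound 2.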